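The source may hold more compounds than are shown below. What is called first, only, known or untested is meant among the compounds shown, and "the series" means these compounds.

In a functional assay for inhibition of sodium/hydrogen exchanger (Oryctolagus cuniculus) (on this read-out higher numbers stand for weaker inhibition and lower numbers for stronger inhibition), compound 1 `CS(=O)(=O)c1cc(C(=O)N=C(N)N)ccc1Oc1cccnc1` gives 76 nM, while compound 2 `CS(=O)(=O)c1cc(C(=O)N=C(N)N)ccc1C1CCCCC1` gives 340 nM, so compound 2 stands highest of the two numbers after the step of a 4.5-fold higher number from compound 1 to compound 2 (0.65 log units; beyond the scatter). Compound 3 `Cc1ccc(C(=O)N=C(N)N)cc1S(C)(=O)=O` carries the change (methyl in place of cyclohexyl on an aromatic carbon). Among the compounds with values here, no measured step swaps cyclohexyl for methyl, and the one step that exists, from compound 1 to compound 2, bears on it only loosely. For compound 3 a small further rise of a 1.8-fold higher number from compound 2 to compound 3 (0.25 log units; within the scatter) in this assay is therefore expected, with the estimate put at 600 nM and a range from 150 nM to 2500 nM.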

Compound 3, half-maximal inhibitory concentration: 210 nM
The estimate for compound 3 lay 2.9-fold (0.46 log units) above the measured number; the measured number falls inside the stated range.
By their numbers in this assay, from the lowest: compound 1; then compounds 3 and 2 (each within the scatter of the next).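

In this assay, the swap of cyclohexyl for methyl on this aromatic carbon gives a 1.6-fold lower number from compound 2 to compound 3 (0.21 log units; within the scatter) and so does not separate the two groups. Methyl stays apart from (pyridin-3-yl)oxy, with a 2.8-fold higher number from compound 1 to compound 3 (0.44 log units; beyond the scatter), as cyclohexyl did, so among these compounds only compound 1 stands clear of the others at this position. From the compounds shown here alone, what remains open is whether a phenoxy group or an amine on this carbon would fall with compound 1 or with compounds 2 and 3. No measurement here offers an explanation for these differences.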